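This account rests on a few compounds, and the source may have more. Where it says the series, first, only, none or still open, it means among the compounds named here.

Compound 2 `CCC#Cc1cn([C@H]2C[C@H](O)[C@@H](CO)O2)c(=O)[nH]c1=O` is a nucleoside analogue that carries a but-1-yn-1-yl chain on the shared core. In a functional assay on L1210 cells (Mus musculus) (a higher number here means a weaker inhibitor, a lower number a stronger inhibitor), compound 2 gives only a limit of the assay, > 1000 ug/mL. Its neighbour, compound 1 `O=c1[nH]c(=O)n([C@H]2C[C@H](O)[C@@H](CO)O2)cc1C#CCCO`, carries a hydroxy at the end of that chain. In this assay compound 1 likewise gives only a limit, > 1000 ug/mL. Among the measured compounds shown here, the one measured step, a step that the two limits leave unreadable from compound 1 to compound 2, is therefore unreadable in size and direction, as both values sit at the same limit, (the limit of > 1000 ug/mL in this assay, at which 2 of the 2 values shown sit).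

Compound 3 `CC#Cc1cn([C@H]2C[C@H](O)[C@@H](CO)O2)c(=O)[nH]c1=O` differs from compound 2 by hydrogen in place of methyl on a saturated chain carbon bound to a triple-bonded carbon. For the measured compounds named here, no measured step bears on a change of this kind, and the single step available shows nothing beyond the limit. For compound 3 the expectation is that this assay again reports a limit rather than a number, and compound 3 is estimated at 1500 ug/mL with a range of 300 ug/mL to 6000 ug/mL. The step that the limit leaves unreadable from compound 2 to compound 3 is accordingly expected to be within the scatter.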

Compound 3, concentration for 50% inhibition: 164 ug/mL
Beside the measured number, compound 3's estimate is 9.1-fold (0.96 log units) above it; measured number below the stated range.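

Compound 3 is the only one of the three with a number rather than a limit in this assay, which shows that this position can respond to a change in the chain. Going from but-1-yn-1-yl to prop-1-yn-1-yl, with hydrogen in place of methyl on a saturated chain carbon bound to a triple-bonded carbon, gives an at least 6.0-fold lower number from compound 2 to compound 3 (0.78 log units; beyond the scatter), and hydrogen in place of hydroxymethyl at the same place gives an at least 6.0-fold lower number from compound 1 to compound 3 (0.78 log units; beyond the scatter). Both sizes are only lower bounds because the two longer chains give no number: the limit of > 1000 ug/mL in this assay, at which 2 of the 3 values shown sit.

As far as these compounds go, the step between the two longer chains cannot be read, so what the hydroxy does there stays open. From the compounds shown here alone, how a shorter ethynyl group, or an amine at the end of the chain, would read in this assay also stays open.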